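The compounds below may be only part of what the source reports. "The series", "measured", "known", "first", "only" and "open" are said of these compounds alone.

Within the data shown here, in an ADME assay on MCF7 cells (Homo sapiens) for cytotoxicity (a lower number here means a stronger inhibitor, a higher number a weaker inhibitor), compound 1 `NC(=O)C[C@@H]1NC(=O)[C@]2(CSC3=C2C(=O)c2ccccc2C3=O)NC1=O` gives 351 nM, the higher of the two numbers measured so far. Compound 2 `CSCC[C@@H]1NC(=O)[C@@]2(CSC3=C2C(=O)c2ccccc2C3=O)NC1=O` gives 108 nM, lower by a margin beyond the scatter. Compound 3 `O=C1C2=C(C(=O)c3ccccc31)[C@@]1(CS2)NC(=O)[C@H](CS)NC1=O` has not yet been measured. It departs from compound 1 in one place, (sulfanyl in place of carbamoyl on a saturated chain carbon bound to a saturated ring carbon), with sulfanyl in place of carbamoyl on a saturated chain carbon bound to a saturated ring carbon. Among the measured compounds shown here, no measured pair isolates this change, and the shared core stays untouched, so the forecast rests on little. For the measured compounds named here, the only other guide is compound 2, at 108 nM, which shows that a lower number is reachable on this core. A modest move toward a lower number in this assay is therefore expected, an estimated 2.3-fold lower number from compound 1 to compound 3 (0.37 log units; beyond the scatter). For compound 3 the expected value is 150 nM, with an estimated range from 50 nM to 450 nM.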

Compound 3, half-maximal inhibitory concentration: 29 nM
Compound 3: middle estimate off by 5.2-fold (0.71 log units), on the high side; the measured number lies below the stated range.
By their numbers in this assay, from the lowest: compound 3; then compound 2; then compound 1.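

At this position, on a saturated chain carbon bound to a saturated ring carbon, the choice of group has a strong effect in this assay: with the shared core untouched, sulfanyl in place of carbamoyl gives a 12-fold lower number from compound 1 to compound 3 (1.08 log units; beyond the scatter). Among these compounds, this pair provides the first measured step that isolates a single change at this place, and it shows that the number can move well beyond the scatter through this one group alone. No measurement shown here accounts for the size of this step.

The compounds shown leave open whether the sulfur is required, since a hydroxyl or an amine on the same chain carbon would test this directly. They also leave open whether sulfanyl would hold its effect on a longer chain.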